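This account rests on a few compounds, and the source may have more. Where it says the series, first, only, none or still open, it means among the compounds named here.

Measured compounds:
Compound 1 `O=C(Nc1cccc(C(=O)O/N=C2\CCCc3noc(-c4ccc(F)cc4)c32)c1)c1cccc(F)c1`: > 25000 nM
Compound 2 `O=C(Nc1cccc(C(=O)O/N=C2\CCCc3noc(-c4cccc(F)c4)c32)c1)c1cccc(F)c1`: 9300 nM
Compound 3 `CC(C)(C)OC(=O)Nc1cccc(C(=O)Nc2cccc(C(=O)O/N=C3\CCCc4onc(-c5ccc(F)cc5)c43)c2)c1`: > 25000 nM

These three share one core and differ in the groups hung on it. In a functional assay on MDA-MB-231 cells (Homo sapiens) for antiproliferative activity, read by MTT assay, with a stated time of 72 h (on this read-out higher numbers stand for weaker inhibition and lower numbers for stronger inhibition), compound 1 gives > 25000 nM, which is a limit of the assay rather than a number. Compound 3 also gives > 25000 nM in this assay, again a limit. Only compound 2 gives a number, 9300 nM in this assay, and the step of an at least 2.6-fold lower number from compound 1 to compound 2 (0.42 log units; beyond the scatter) comes from swapping 3-fluorophenyl for 4-fluorophenyl on an aromatic carbon of the core. So compound 1 stands at the upper edge of what this set can show, as the limit of > 25000 nM in this assay, at which 2 of the 3 values shown sit, makes plain.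

Compound 4 `Nc1cccc(C(=O)Nc2cccc(C(=O)O/N=C3\CCCc4noc(-c5ccc(F)cc5)c43)c2)c1` is not yet measured. It differs from compound 1 by amino in place of fluoro on an aromatic carbon. Among the measured compounds shown here, no measured step covers this change; the one step in hand, from compound 1 to compound 2, touches a different ring. The two limits give no reason to expect a strong compound, and the change itself has no measured counterpart here. Compound 4 is therefore expected to stay weak, with an estimate of 30000 nM in this assay, between 10000 nM and 90000 nM. That estimate means an expected step that the limit leaves unreadable from compound 1 to compound 4.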

Compound 4, half-maximal inhibitory concentration: > 25000 nM
Compound 4: no number, only a limit; the forecaster's own chance of this, stated with the estimate: 65%; the middle value does not contradict the limit.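

In this assay, compound 4 gives > 25000 nM, which is a limit of the assay and not a number. Compound 1 also sits at a limit, so no step can be read between compound 1 and compound 4. The compounds shown leave open whether amino in place of fluoro changes the activity at all.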